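Shrinking the aromatic alkyl group from tert-butyl to methyl

The compounds below may be only part of what the source reports. "The series", "measured", "known", "first", "only" and "open" are said of these compounds alone.

In a functional assay on MCF7 cells (Homo sapiens) for antiproliferative activity, read by sulforhodamine B assay, with a stated time of 48 h (a lower number here means a stronger inhibitor, a higher number a weaker inhibitor), compound 3 `CC(C)(C)c1ccc(NS(=O)(=O)c2ccc(N3CCNC3=O)cc2)cc1` reaches only the limit of > 1000 nM, not a number. Compound 1 `CCCCCc1ccc(NS(=O)(=O)c2ccc(N3CCNC3=O)cc2)cc1` likewise gives only the limit of > 1000 nM in this assay. Compound 2 `Cc1cccc(NS(=O)(=O)c2ccc(N3CCNC3=O)cc2)c1C` gives 230 nM in this assay. Among the measured compounds shown here, the one measured step, a step that the two limits leave unreadable from compound 1 to compound 3, cannot be read because of the limit of > 1000 nM in this assay, at which 2 of the 3 values shown sit. Compound 4 `Cc1ccc(NS(=O)(=O)c2ccc(N3CCNC3=O)cc2)cc1` differs from compound 3 by methyl in place of tert-butyl on an aromatic carbon. For the measured compounds named here, no measured step mirrors this change, so the estimate rests on where compound 2 stands with its two methyl groups and on the limit shared by compound 1 and compound 3. A gain in this assay is expected, so compound 4 is estimated at 500 nM, between 150 nM and 1500 nM, which would mean a step of an at least 2.0-fold lower number from compound 3 to compound 4 (0.30 log units; that floor lies within the scatter).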

Compound 4, half-maximal inhibitory concentration: 610 nM
Compound 4: the middle estimate sits 1.2-fold (0.09 log units) below what was measured; low and high end bracket the measured number.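

Methyl on this aromatic carbon gives a measured number in this assay where tert-butyl and pentyl give only limits, with an at least 1.6-fold lower number from compound 3 to compound 4 (0.21 log units; that floor lies within the scatter) and an at least 1.6-fold lower number from compound 1 to compound 4 (0.21 log units; that floor lies within the scatter) as floors within the scatter. The true size of these steps cannot be read because compound 1 and compound 3 each sit at a limit: the limit of > 1000 nM in this assay, at which 2 of the 4 values shown sit. Moving from 2,3-dimethylphenyl to 4-methylphenyl on the sulfonamide nitrogen gives a 2.7-fold higher number from compound 2 to compound 4 (0.42 log units; beyond the scatter) and so the single methyl group does not match the pair in compound 2.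

Where ethyl or isopropyl on this aromatic carbon would fall stays open. So does what a methoxy group or an amine would give there.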